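A few compounds are considered here, and "the series" means these few. Any claim that something is new, unique, unknown or untested is made for them only; others in the source may bear on it.

Measured in a functional assay on cells (Cancer cell lines, Homo sapiens) for cytotoxicity, with a stated time of 48 h; a higher number here means a weaker inhibitor of growth, a lower number a stronger inhibitor of growth:
- compound 1 `COc1ccc(CN2C(=O)/C(=C\c3cc(OC)c(OC)c(OC)c3)c3ccccc32)cc1`: 10500 nM
- compound 2 `COc1cc(/C=C2/C(=O)N(C)c3ccc(O)cc32)cc(OC)c1OC`: 17400 nM

Compound 2 stands at 17400 nM, within the scatter of compound 1 at 10500 nM. Compound 3 `COc1ccc2c(c1)/C(=C\c1cc(OC)c(OC)c(OC)c1)C(=O)N2C` departs from compound 2 by methyl in place of hydrogen on an oxygen on an aromatic ring, that is, hydroxy to methoxy. Among the measured compounds shown here, no measured step covers this change. Compound 1 at 10500 nM and compound 2 at 17400 nM differ in more than one place, yet their values lie within the scatter of each other. A single small change is therefore expected to give no shift beyond the scatter in this assay. The expected change, a 1.5-fold lower number from compound 2 to compound 3 (0.16 log units; within the scatter), stays within that scatter. For compound 3 the estimate is 12000 nM, with an expected range of 4000 nM to 30000 nM.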

Compound 3, concentration for total growth inhibition: 14100 nM
The estimate for compound 3 lay 1.2-fold (0.07 log units) below the measured number; the measured number falls inside the stated range.
By their numbers in this assay, from the lowest: compounds 1, 3 and 2 (each within the scatter of the next).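

Hydroxy to methoxy on the aromatic ring gives a 1.2-fold lower number from compound 2 to compound 3 (0.09 log units; within the scatter) in this assay and is the first change in the series that can be read at a single place. At this oxygen, methyl in place of hydrogen therefore moves the number by no more than the scatter, whereas compound 1 and compound 2 differ in more than one place and could only hint at such a flat reading. Nothing at hand bears on what lies behind this step.

Only hydrogen and methyl are shown on this oxygen, so a longer chain such as ethyl, or a chain ending in an amine or a carboxylic acid, remains open. Among the compounds shown here, also open is whether changes elsewhere on the shared core would stay as flat, since no other single-place step is available.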